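The source may hold more compounds than are shown below. What is called first, only, known or untested is meant among the compounds shown, and "the series" means these compounds.

Measured compounds:
Compound 1 `O=C(Nc1nn[nH]n1)c1cc(Cl)cc(-c2ccc(Cl)cc2)n1` in a functional assay on the whole organism with Rattus norvegicus as the target, at a dose of 3 mg/kg by the oral route (on this read-out higher numbers stand for a stronger effect at the one dose given and lower numbers for a weaker effect), gives 11%.
Compound 2 `Nc1ccc(-c2cc(Cl)cc(C(=O)Nc3nn[nH]n3)n2)cc1` in this assay gives 100%.

Among the compounds with values here, of these two numbers, compound 2 stands highest; its only neighbour is compound 1, which lies a number 89 percentage points higher from compound 1 to compound 2 (beyond the scatter) below it, a step brought about by amino in place of chloro on an aromatic carbon of the phenyl ring. Compound 3 `CCOc1cc(C(=O)Nc2nn[nH]n2)nc(-c2ccc(N)cc2)c1` has not yet been measured in this assay. It differs from compound 2 by ethoxy in place of chloro on an aromatic carbon. Within the data shown here, no measured step bears directly on this change: the single step, from compound 1 to compound 2, concerns the aminophenyl group and not the ring with one nitrogen, so nothing here shows how an ethoxy at that place behaves. Because compound 2 already gives 100%, the number can hardly rise. For compound 3 the expected step is a number 20 percentage points lower from compound 2 to compound 3 (beyond the scatter). Compound 3 is therefore estimated at 80%, with a range from 40% to 100%.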

Compound 3, a percentage reported as inhibition, in the whole organism at one dose (the size of the read-out at that dose, not a potency): 62%
Estimate against measurement, compound 3: 18 percentage points above, within the range that was stated.
By their numbers in this assay, from the lowest: compound 1; then compound 3; then compound 2.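

This is the first change shown at the place opposite the ring nitrogen, as the earlier step lay on the phenyl ring. In this assay, ethoxy in place of chloro on an aromatic carbon gives a number 38 percentage points lower from compound 2 to compound 3 (beyond the scatter), so the group at this place does bear on the read-out, and chloro cannot be exchanged for ethoxy without a clear loss at this dose, though compound 3 still gives 62% with the 4-aminophenyl group in place. Nothing available gives a measured reason for this step, so the loss stands as an observation only.

The compounds shown leave open whether the loss goes with the oxygen attached to the ring or with the two-carbon chain beyond it, a question that methoxy, a longer chain such as propoxy, or a plain hydrogen at this place would begin to address. They also leave open how an amine or a carboxylic acid would behave here, and whether ethoxy would bring a step of similar size if the 4-chlorophenyl group of compound 1 stood in place of the 4-aminophenyl group.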